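Swapping the aryl hydrazone end of a thiosemicarbazone

A few compounds are considered here, and "the series" means these few. Any claim that something is new, unique, unknown or untested is made for them only; others in the source may bear on it.

Measured so far:
- Compound 1 `COc1ccc(/C=N\NC(=S)NC(C)(C)CCC[C@](C)(O)[C@@H]2CC=C(C)CC2)cc1`: 76100 nM
- Compound 2 `CC1=CC[C@@H]([C@@](C)(O)CCCC(C)(C)NC(=S)N/N=C\c2ccc(Cl)cc2)CC1`: 22700 nM

Both compounds share one core and differ only at the aromatic end of the hydrazone. In a functional assay on PCO3 cells (Homo sapiens) for cytotoxicity, read by sulforhodamine B assay (on this read-out higher numbers stand for weaker inhibition of growth and lower numbers for stronger inhibition of growth), compound 1 gives 76100 nM, while compound 2 gives 22700 nM. Within the data shown here, the single measured step, a 3.4-fold lower number from compound 1 to compound 2 (0.53 log units; beyond the scatter), places compound 2 as the lower of the two numbers, so within this small set it is the stronger inhibitor of growth.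

Compound 3 `CC1=CC[C@@H]([C@@](C)(O)CCCC(C)(C)NC(=S)N/N=C(/C)c2ccccc2)CC1` carries the change (a group of 9 heavy atoms (8 carbon, 1 nitrogen; one six-membered aromatic ring of carbon only) in place of a group of 9 heavy atoms (7 carbon, 1 nitrogen, 1 chlorine; one six-membered aromatic ring of carbon only), on an amide-type nitrogen). Here the chlorine leaves the aromatic ring and a methyl appears on the double-bonded carbon of the hydrazone. Among the measured compounds shown here, no measured step matches this change; the only step recorded, from compound 1 to compound 2, concerns a different substituent swap and was modest. For the measured compounds named here, with that as the sole guide, a step of similar or smaller size is expected in this assay, most likely back toward a higher number, though a result within the scatter cannot be excluded.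

Compound 3 is therefore expected to give roughly 38000 nM, between 13000 nM and 110000 nM, which corresponds to an expected step of a 1.7-fold higher number from compound 2 to compound 3 (0.22 log units; within the scatter).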

Compound 3, concentration for total growth inhibition: > 100000 nM
Compound 3 ended at the assay's limit (the forecaster's own chance of this, stated with the estimate: 5%); middle value at least 2.6-fold (0.42 log units) from the limit.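

Compound 3 sits at a limit of this assay, which is a limit and not a number: the limit of > 100000 nM in this assay, at which 1 of the 3 values shown sits. Even so, the swap at this amide-type nitrogen, whose other neighbour is the thiocarbonyl carbon, can be read in one direction: the group of 9 heavy atoms with 8 carbon and 1 nitrogen gives weaker inhibition of growth than the group with 7 carbon, 1 nitrogen and 1 chlorine, with an at least 4.4-fold higher number from compound 2 to compound 3 (0.64 log units; beyond the scatter), so this end of the molecule tolerates the change less well than the single earlier step suggested. Against the methoxy compound, the limit leaves only a floor, an at least 1.3-fold higher number from compound 1 to compound 3 (0.11 log units; that floor lies within the scatter), so these two cannot be put in order.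

The step from the chloro compound mixes two differences, the loss of the chlorine and the gain of a carbon, and nothing shown separates them, as no compound here carries one difference without the other. Going by these compounds, it also stays open how an amine or a carboxylic acid in place of the chloro on the aromatic carbon would read in this assay.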